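A few compounds are considered here, and "the series" means these few. Any claim that something is new, unique, unknown or untested is made for them only; others in the source may bear on it.

Compounds measured so far:
- compound 1, `c1ccc(CNC(c2ccc[nH]2)c2nnc(-c3ccccc3)o2)cc1`: 187000 nM
- compound 2, `Clc1cccc(-c2nnc(C(NCc3ccccc3)c3ccc[nH]3)o2)c1`: 62200 nM
- compound 3, `Clc1ccc(-c2nnc(C(NCc3ccccc3)c3ccc[nH]3)o2)cc1Cl`: 25500 nM

All three share one core and differ only in the aromatic group attached to it. In a functional assay on A549 cells (Homo sapiens) for cytotoxicity, read by MTT assay, with a stated time of 24 h (on this read-out higher numbers stand for weaker inhibition and lower numbers for stronger inhibition), compound 3 gives the lowest number of the three, so it is the strongest inhibitor here: compound 2 sits a 2.4-fold lower number from compound 2 to compound 3 (0.39 log units; beyond the scatter) above it, and compound 1 sits a 7.3-fold lower number from compound 1 to compound 3 (0.87 log units; beyond the scatter) above it.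

Compound 4, `Cc1cccc(-c2nnc(C(NCc3ccccc3)c3ccc[nH]3)o2)c1`, has not been measured. It differs from compound 3 in this way: 3-methylphenyl in place of 3,4-dichlorophenyl on an aromatic carbon. Among the measured compounds shown here, two measured steps bear on this change. For the measured compounds named here, removing a chloro is the reverse of the step of a 2.4-fold lower number from compound 2 to compound 3 (0.39 log units; beyond the scatter), and the remaining chloro is exchanged for a methyl group, a swap for which no measured step exists. Since adding each chloro lowered the number by a modest amount (a 3.0-fold lower number from compound 1 to compound 2 (0.48 log units; beyond the scatter) and a 2.4-fold lower number from compound 2 to compound 3 (0.39 log units; beyond the scatter)), taking both away is expected to move the number back up; the methyl may recover part of that, but nothing measured shows how much.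

The expected step is therefore a 2.7-fold higher number from compound 3 to compound 4 (0.44 log units; beyond the scatter), beyond the scatter. Compound 4 is estimated at 70000 nM in this assay, within a range of 30000 nM to 160000 nM.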

Compound 4, half-maximal inhibitory concentration: 431000 nM
The estimate for compound 4 lay 6.2-fold (0.79 log units) below the measured number; measured number above the stated range.
By their numbers in this assay, from the lowest: compound 3; then compound 2; then compound 1; then compound 4.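

In this assay, methyl in place of hydrogen gives a 2.3-fold higher number from compound 1 to compound 4 (0.36 log units; beyond the scatter), the opposite direction from chloro in place of hydrogen, which gives a 3.0-fold lower number from compound 1 to compound 2 (0.48 log units; beyond the scatter). Methyl in place of chloro therefore gives a 6.9-fold higher number from compound 2 to compound 4 (0.84 log units; beyond the scatter), and the full exchange of 3,4-dichlorophenyl for 3-methylphenyl gives a 17-fold higher number from compound 3 to compound 4 (1.23 log units; beyond the scatter), which leaves compound 4 as the weakest inhibitor of the four. So a group added to this aromatic ring can shift the number either way, depending on which group it is, and no measurement available here explains the difference.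

As far as these compounds go, it remains open whether a fluoro, a methoxy or an amino group on this ring would behave more like chloro or like methyl. From the compounds shown here alone, it is also open whether a 3,4-dimethylphenyl group would raise the number further still.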